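The source may hold more compounds than are shown below. What is called first, only, known or untested is meant among the compounds shown, and "the series" means these compounds.

Compound 1, `CCc1cccc(C[C@H](O)/C=C/[C@H]2COC(=O)N2CCSCCCC(=O)O)c1`, is measured in an assay on CHO cells for displacement of a labelled ligand from prostaglandin E2 receptor EP4 subtype (Mus musculus), read by scintillation counting, with a stated time of 60 min (on this read-out higher numbers stand for weaker inhibition and lower numbers for stronger inhibition), and gives 7.9 nM. Among the three compounds measured so far, compound 1 carries the highest number; compound 3, `O=C(O)CCCSCCN1C(=O)SC[C@@H]1/C=C/[C@@H](O)Cc1cccc(C(F)(F)F)c1`, gives 0.97 nM in this assay, and compound 2, `CCCc1cccc(C[C@H](O)/C=C/[C@H]2CCC(=S)N2CCCCCCC(=O)O)c1`, gives 0.4 nM, both of them separated from compound 1 by gaps that lie beyond the scatter. Compound 4, `O=C(O)CCCSCCN1C(=O)OC[C@@H]1/C=C/[C@@H](O)Cc1cccc(C(F)(F)F)c1`, has not yet been measured in this assay. It differs from compound 1 in a single place: trifluoromethyl in place of ethyl on an aromatic carbon. Compound 4 shares the trifluoromethyl group and the chain of compound 3 and differs from compound 3 only in its core, which is that of compound 1. Since compound 3 gives 0.97 nM, compound 4 is expected to land close to it, so the step from compound 1 to compound 4 is estimated as a drop beyond the scatter, a 5.3-fold lower number from compound 1 to compound 4 (0.72 log units; beyond the scatter). The value of compound 4 in this assay is estimated at 1.5 nM, within a range from 0.5 nM to 5 nM.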

Compound 4, inhibition constant: 2 nM
Estimate against measurement, compound 4: 1.3-fold (0.12 log units) below; the range from low to high includes it.
By their numbers in this assay, from the lowest: compound 2; then compound 3; then compound 4; then compound 1.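

Trifluoromethyl in place of ethyl on an aromatic carbon gives, in this assay, a 4.0-fold lower number from compound 1 to compound 4 (0.60 log units; beyond the scatter), with the core and the chain held constant. Going by these compounds alone, this is the first comparison that isolates one change, as the earlier compounds differed from one another in more than one place, and it shows that the group at this position alone can move the number beyond the scatter. No measurement shown here explains why this exchange has this effect.

The compounds shown leave open how a chlorine atom, a methoxy group or a hydrogen would read at this position on the same core and chain. They also leave open whether the same exchange would give a step of similar size on the core and chain of compound 2.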